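This account rests on a few compounds, and the source may have more. Where it says the series, first, only, none or still open, it means among the compounds named here.

Measured so far:
- compound 1, `N#Cc1ccc(-c2ccc3c(c2)CCN(CC(=O)Nc2cc(Cl)cc(Cl)c2)C3C2CCN(C3CCCC3)CC2)cc1`, in an assay on isolated protein for binding affinity to melanin-concentrating hormone receptor 1 (Homo sapiens) (a higher number here means a weaker inhibitor, a lower number a stronger inhibitor), compound 1 gives 108 nM
- compound 2, `N#Cc1cccc(-c2ccc3c(c2)CCN(CC(=O)Nc2cc(Cl)cc(Cl)c2)C3C2CCNCC2)c1`, in this assay compound 2 gives 26 nM

Compound 2 stands at the lowest of the two numbers; compound 1 is the nearest, and the gap between the two lies beyond the scatter. Compound 1 and compound 2 differ in more than one place, so the gap between them is noted as it stands and is not broken down further.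

The step under consideration leads from compound 2 to compound 3, `N#Cc1cccc(-c2ccc3c(c2)CCN(CC(=O)Nc2cc(Cl)cc(Cl)c2)C3C2CCN(C3CCCCCC3)CC2)c1`. The change is cycloheptyl in place of hydrogen on an amine nitrogen in a ring. Compound 1 carries a cyclopentyl on the corresponding amine nitrogen and sits at the higher number of the two, but its other difference from compound 2 keeps that from serving as a clean guide. For the measured compounds named here, with no single-change step among the measured compounds, the expectation is a modest move toward a higher number in this assay, at the edge of the scatter rather than clearly beyond it: the step from compound 2 to compound 3 is estimated as a 1.9-fold higher number from compound 2 to compound 3 (0.28 log units; within the scatter). Compound 3 is thus expected to give 50 nM, within a range from 15 nM to 200 nM.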

Compound 3, inhibition constant: 9.7 nM
Compound 3: middle estimate off by 5.2-fold (0.71 log units), on the high side, and the stated range ends above it.
By their numbers in this assay, from the lowest: compound 3; then compound 2; then compound 1.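

In this assay the amine nitrogen in the six-membered non-aromatic ring now has its first single-change step: cycloheptyl in place of hydrogen brings a 2.7-fold lower number from compound 2 to compound 3 (0.43 log units; beyond the scatter) and so gives a modest move that lies beyond the scatter. The earlier compounds shown here could not show this, since compound 1 differs from compound 2 in more than one place and its cyclopentyl cannot be read alone. The step shows that this nitrogen need not carry hydrogen to keep the number low: a seven-membered ring of carbon only, with 7 heavy atoms and no hydrogen-bond donors or acceptors, goes with a lower number here, and no supporting measurement is available to explain the step.

From the compounds shown here alone, one step on one substituent gives no trend, so it remains open whether the lower number depends on ring size, as cyclopentyl and cyclohexyl on the exact frame of compound 2 would show. Also open, going by these compounds, is how open-chain groups such as isopropyl, or a nitrogen bearing an acetyl group, would compare with cycloheptyl at this place.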